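The source may hold more compounds than are shown below. What is called first, only, known or untested is meant among the compounds shown, and "the series" means these compounds.

Compound 1 `CC(C)CC/N=C(\NC#N)Nc1cc(C(F)(F)F)cc(C(F)(F)F)c1` — 5600 nM
Compound 2 `CC(C)CC/N=C(\NC#N)Nc1cc(F)cc(F)c1` — 85000 nM
Compound 3 `COc1cc(N/C(=N/C2CCCC2)NC#N)cc(C(F)(F)F)c1` — 75000 nM

Of the compounds shown here, three sharing one core have been measured in a functional assay (aorta) with Rattus norvegicus as the target; a lower number here means a stronger inhibitor, a higher number a weaker inhibitor. Compound 1 gives 5600 nM, the lowest of the three numbers. Compound 3 gives 75000 nM, and compound 2 gives 85000 nM, so both stand beyond the scatter above compound 1. No two of these compounds differ in only one place, so no single structural step has been measured, and the gaps to compound 2 and compound 3 each involve more than one change.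

Compound 4 `CC(C)C(C)/N=C(\NC#N)Nc1cc(C(F)(F)F)cc(C(F)(F)F)c1` is not yet measured. It differs from compound 1 in one place: 1,2-dimethylpropyl in place of isopentyl on a double-bonded nitrogen. The two compounds hold the same atoms, joined differently, so the change is one of branching within a chain of five carbon atoms rather than of size or polarity. Going by the values given here, the measured set offers no step that isolates such a rearrangement; a small step in this assay is expected, leaning toward a higher number but not clearly beyond the scatter. The step of a 1.4-fold higher number from compound 1 to compound 4 (0.15 log units; within the scatter) is therefore expected to be modest. Compound 4 is estimated to give 8000 nM, within a range from 2500 nM to 30000 nM.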

Compound 4, half-maximal inhibitory concentration: 17600 nM
For compound 4 the middle estimate is 2.2-fold (0.34 log units) below the measured one; the measured number falls inside the stated range.
By their numbers in this assay, from the lowest: compound 1; then compound 4; then compounds 3 and 2 (each within the scatter of the next).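

In this assay, going by these compounds alone, the step of a 3.1-fold higher number from compound 1 to compound 4 (0.50 log units; beyond the scatter) is the first change in a single place in this set, and it lies beyond the scatter. It shows that on the double-bonded nitrogen, rearranging the same carbon atoms is enough to shift the number, with 1,2-dimethylpropyl giving a weaker inhibitor than isopentyl. Nothing available here accounts for this difference.

The compounds shown leave open how a straight pentyl chain, a tert-butyl group or a longer chain would compare with isopentyl at this position. From the compounds shown here alone, it also remains open whether the same exchange of isopentyl for 1,2-dimethylpropyl would give a step of similar size on the core of compound 2, which carries fluorine atoms in place of trifluoromethyl groups.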